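From a Fluorophenyl Arm to a Thiophene Arm

A few compounds are considered here, and "the series" means these few. Any claim that something is new, unique, unknown or untested is made for them only; others in the source may bear on it.

Compound 1 `COc1ccc(/C=N/NC(=S)NC(C)(C)[C@H]2CC=C(C)CC2)cc1` is measured in a functional assay on K562 cells (Homo sapiens) for inhibition, read by sulforhodamine B assay, with a stated time of 48 h (a lower number here means a stronger inhibitor of growth, a higher number a weaker inhibitor of growth), where compound 1 gives 30700 nM. Compound 2 `CC1=CC[C@H](C(C)(C)NC(=S)N/N=C/c2ccc(F)cc2)CC1` carries fluoro in place of methoxy on an aromatic carbon, and the step of an at least 3.2-fold higher number from compound 1 to compound 2 (0.51 log units; beyond the scatter) lies beyond the scatter. In this assay compound 2 reaches only a limit, > 100000 nM, and not a number, as seen in the limit of > 100000 nM in this assay, at which 1 of the 2 values shown sits. Compound 3 `CC1=CC[C@H](C(C)(C)NC(=S)N/N=C/c2cccs2)CC1` differs from compound 2 in one place: thiophen-2-yl in place of 4-fluorophenyl on a carbon with a double bond to nitrogen. No measured step touches this exchange of one aromatic ring for another; the single step shown, an at least 3.2-fold higher number from compound 1 to compound 2 (0.51 log units; beyond the scatter), concerns a substituent on the ring that now leaves and gives no direct guide. Since compound 2 stands at a limit in this assay, neither the direction nor the size of the move to compound 3 can be read from the data. Compound 3 is therefore estimated at 60000 nM, within 15000 nM to 200000 nM, which corresponds to an expected step of an at least 1.6-fold lower number from compound 2 to compound 3 (0.22 log units; that floor lies within the scatter).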

Compound 3, concentration for total growth inhibition: > 100000 nM
Compound 3: no number, only a limit; the forecaster's own chance of this, stated with the estimate: 50%; middle value at least 1.6-fold (0.22 log units) from the limit.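

In this assay compound 3 gives > 100000 nM as a limit of the assay and not a number. At this carbon with a double bond to nitrogen, thiophen-2-yl in place of 4-methoxyphenyl gives an at least 3.2-fold higher number from compound 1 to compound 3 (0.51 log units; beyond the scatter) and so points the same way as the earlier change of methoxy to fluoro, which means that a second, different replacement of the 4-methoxyphenyl arm also fails to keep a measurable value. The step between the 4-fluorophenyl and thiophen-2-yl arms cannot be read, so nothing can be said about how these two arms rank.

Of the compounds shown, only compound 1 gives a number, so it remains open what a ring carrying an amine or a longer alkoxy chain in place of methoxy would give. Any such comparison is bounded by one fact so far: the limit of > 100000 nM in this assay, at which 2 of the 3 values shown sit.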